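From cyclobutyl to pyridin-2-yl on a carbonyl carbon

The compounds below may be only part of what the source reports. "The series", "measured", "known", "first", "only" and "open" are said of these compounds alone.

In a physicochemical assay for lipophilicity, read by HPLC, measured as chromatographic lipophilicity, at pH 7.4 (on this read-out lower numbers stand for lower lipophilicity and higher numbers for higher lipophilicity), compound 1 (`C[C@@H]1C=NN(C(=O)C(C)(C)C)[C@@H]1c1ccccc1`) gives 6.5 and compound 2 (`O=C(C1CCC1)N1N=CCC1c1ccccc1`) gives 4.7 on the same scale. Compound 2 therefore holds the lower of the two numbers, and its gap to compound 1 lies beyond the scatter. Among the measured compounds shown here, the two measured compounds do not differ in a single place, so they offer no step that isolates one change. Compound 3 (`O=C(c1ccccn1)N1N=CCC1c1ccccc1`) keeps the rest of compound 2 and carries pyridin-2-yl in place of cyclobutyl on a carbonyl carbon. The entering group is a six-membered aromatic ring with 1 hetero atom and brings a hydrogen-bond acceptor, and cyclobutyl has none. For the measured compounds named here, no measured pair shows this exchange, so the expectation rests on the structural change alone, starting from compound 2 at 4.7 in this assay as the reference. A fall beyond the scatter is expected, and the estimated move is a number 0.70 log units lower from compound 2 to compound 3 (beyond the scatter) on this scale. Compound 3 is estimated at 4 with an expected range from 3.4 to 4.6 in this assay before any measurement.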

Compound 3, distribution coefficient: 2.4
Compound 3: middle estimate off by 1.60 log units, on the high side, outside the stated range (below it).
By their numbers in this assay, from the lowest: compound 3; then compound 2; then compound 1.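

In this assay, the exchange of cyclobutyl for pyridin-2-yl on a carbonyl carbon whose other neighbours are an amide-type nitrogen in a ring amounts to a number 2.30 log units lower from compound 2 to compound 3 (beyond the scatter) and is a large step. The two earlier compounds differ in more than one place and gave no reading of any single change, whereas this pair shows that the number responds strongly to the group carried at this place, with compound 3 standing at 2.4 on this scale. The exchange alters the ring size, the aromatic character and the hetero atom together, and nothing measured here tells which of these carries the step or accounts for its size.

The compounds shown leave open how much of the step belongs to the ring nitrogen, a question that phenyl, pyridin-3-yl or pyridin-4-yl on the same carbonyl carbon would separate from the aromatic ring itself. They also leave open whether the same exchange would move the number by a similar amount on the core of compound 1.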